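Adding a methyl to the carboxy group of compound 3

This account rests on a few compounds, and the source may have more. Where it says the series, first, only, none or still open, it means among the compounds named here.

In an ADME assay for permeability, using PAMPA, at pH 7.4 (on this read-out lower numbers stand for lower permeability and higher numbers for higher permeability), three compounds have been measured:
- Compound 1 `Cc1ccc(-c2nc3ccccc3s2)cc1NC(=O)c1cc([N+](=O)[O-])c(N2CCC(C(=O)O)CC2)cc1Cl` gives 17 10^-6 cm/s
- Compound 2 `COC(=O)C1CCN(c2cc(Cl)c(C(=O)Nc3cc(-c4nc5ccccc5s4)ccc3C)cc2[N+](=O)[O-])CC1` gives 24 10^-6 cm/s
- Compound 3 `COc1ccc(-c2nc3ccccc3s2)cc1NC(=O)c1cc([N+](=O)[O-])c(N2CCC(C(=O)O)CC2)cc1Cl` gives 5 10^-6 cm/s

Compound 3 has the lowest of these three numbers. It lies clearly under the other two, and the gap to each is beyond the usual scatter of repeated measurements.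

The next compound to be measured is compound 4 `COC(=O)C1CCN(c2cc(Cl)c(C(=O)Nc3cc(-c4nc5ccccc5s4)ccc3OC)cc2[N+](=O)[O-])CC1` and it differs from compound 3 by one small change: methyl in place of hydrogen on an oxygen next to a carbonyl group. This is methyl in place of hydrogen on an oxygen next to a carbonyl group, which turns carboxy into methoxycarbonyl.

The same change has been measured only once, as a 1.4-fold higher number from compound 1 to compound 2 (0.15 log units; within the scatter). That step is small and does not stand out from the scatter. The other measured step, a 3.4-fold lower number from compound 1 to compound 3 (0.53 log units; beyond the scatter), is methoxy in place of methyl on an aromatic carbon. It is a different change, so it gives no size for this one, but it sets the lower starting point.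

No step beyond the scatter is therefore expected in this assay, only a possible slight rise. The expected step is a 1.4-fold higher number from compound 3 to compound 4 (0.15 log units; within the scatter), and this is an estimate from a single example. For compound 4 the estimated value is 7 10^-6 cm/s, with an expected range from 3.5 10^-6 cm/s to 16 10^-6 cm/s as its limits.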

Compound 4, apparent permeability: < 1 10^-6 cm/s
Compound 4: a limit, no number; the forecaster's own chance of this, stated with the estimate: 3%; middle value at least 7.0-fold (0.84 log units) away from the limit.
By their numbers in this assay, from the lowest: compound 3; then compounds 1 and 2 (each within the scatter of the next). At a limit, below all of these: compound 4.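

The value of compound 4, < 1 10^-6 cm/s, is a limit of the assay and not a number. Methyl in place of hydrogen on an oxygen next to a carbonyl group, which earlier looked like a small change, has no single size in this assay: with methoxy in place of methyl on the aromatic carbon it gives an at least 5.0-fold lower number from compound 3 to compound 4 (0.69 log units; beyond the scatter), and the comparison across the two cores reads: the same change on two cores in this assay, a 1.4-fold higher number (0.15 log units; within the scatter) from compound 1 to compound 2 and an at least 5.0-fold lower number (0.69 log units; beyond the scatter) from compound 3 to compound 4, at least 7.0-fold (0.84 log units) apart, beyond the scatter of two such steps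

Methoxy in place of methyl on an aromatic carbon likewise depends on whether carboxy or methoxycarbonyl is present, as it gives an at least 24-fold lower number from compound 2 to compound 4 (1.38 log units; beyond the scatter), and the comparison with the carboxy pair reads: the same change on two cores in this assay, a 3.4-fold lower number (0.53 log units; beyond the scatter) from compound 1 to compound 3 and an at least 24-fold lower number (1.38 log units; beyond the scatter) from compound 2 to compound 4, at least 7.0-fold (0.84 log units) apart, beyond the scatter of two such steps

The compounds shown leave open how far compound 4 really lies under its limit, so the full size of both steps stays unknown. They also leave open whether a longer ester such as ethoxycarbonyl, or a primary amide in place of carboxy, would follow methoxycarbonyl on these two cores, since this interplay rests on a single set of four compounds.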